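Series notes: methyl to fluoro exchange on two cores

The source may report more compounds than this note shows. Statements on the series, on what has been measured and on what is new or still open speak of the compounds shown alone.

Compound 2 `Cc1ccc(N2C(=O)COc3ccc(-c4cnc(Cl)c(NS(=O)(=O)c5ccc(F)cc5)c4)cc32)cc1` gives in a functional assay on HeLa cells (Homo sapiens) for antiproliferative activity, read by MTT assay, with a stated time of 72 h (a higher number here means a weaker inhibitor, a lower number a stronger inhibitor), a value of 32300 nM. Compound 1 `O=C1COc2ccc(-c3cnc(Cl)c(NS(=O)(=O)c4ccc(F)cc4)c3)cc2N1c1ccc(F)cc1` differs from it in one place, (fluoro in place of methyl on an aromatic carbon). For compound 1 in this assay only a limit is reported, > 40000 nM. The step of an at least 1.2-fold higher number from compound 2 to compound 1 (0.09 log units; that floor lies within the scatter) thus ends at a limit rather than a number, and its floor lies within the scatter. Compound 3 `Cc1ccc(N2C(=O)COc3ccc(-c4cccc(NS(=O)(=O)c5ccc(F)cc5)c4)cc32)cc1` carries the same methyl-bearing group but on a different core; the difference between the two cores is not broken down here. For compound 3 in this assay only a limit is known, > 40000 nM. Compound 4 `O=C1COc2ccc(-c3cccc(NS(=O)(=O)c4ccc(F)cc4)c3)cc2N1c1ccc(F)cc1`, not yet measured, relates to compound 3 as compound 1 relates to compound 2: fluoro in place of methyl on an aromatic carbon, the same change at the same place. Because (the limit of > 40000 nM in this assay, at which 2 of the 3 values shown sit), this exchange cannot be resolved on either core with the present data. By analogy with the measured exchange, the step from compound 3 to compound 4 is expected to be a step that the limit leaves unreadable from compound 3 to compound 4. Compound 4 is expected to give about 50000 nM, between 25000 nM and 120000 nM, and most likely again only as a limit.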

Compound 4, half-maximal inhibitory concentration: > 40000 nM
Compound 4: no number, only a limit; the forecaster's own chance of this, stated with the estimate: 80%; the middle value does not contradict the limit.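

In this assay, the exchange of methyl for fluoro gives no readable step between compound 3 and compound 4, since each of the two stands only as a limit: the limit of > 40000 nM in this assay, at which 3 of the 4 values shown sit.

The compounds shown leave open whether 4-methylphenyl and 4-fluorophenyl differ in antiproliferative activity on either core.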